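Swapping methyl for chloro on a thiadiazine-fused triazole

This account rests on a few compounds, and the source may have more. Where it says the series, first, only, none or still open, it means among the compounds named here.

Two measured compounds set the scene. In a functional assay on Huh-7 cells (Homo sapiens) for inhibition, read by sulforhodamine B assay, with a stated time of 72 h (on this read-out higher numbers stand for weaker inhibition and lower numbers for stronger inhibition), compound 1 `COc1ccc2cc(C(C)c3nnc4n3N=C(c3ccc(C)cc3)CS4)ccc2c1` gives 8200 nM. Compound 2 `CC(c1ccc(-c2ccccc2)c(F)c1)c1nnc2n1N=C(c1ccc(Br)cc1)CS2` gives 5000 nM in this assay. These two numbers lie within the usual scatter of each other, so compound 1 cannot be separated from compound 2 on potency; neither can be called the stronger or weaker of the pair.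

Compound 3 `COc1ccc2cc(C(C)c3nnc4n3N=C(c3ccc(Cl)cc3)CS4)ccc2c1` is not yet measured. It differs from compound 1 in one place: chloro in place of methyl on an aromatic carbon. Cut one bond further out, the same change reads 4-methylphenyl to 4-chlorophenyl, while the shared core and the rest of compound 1 are kept.

Among the compounds with values here, no measured pair shows this exact exchange, so there is nothing to lean on beyond the two values above. The expected step from compound 1 to compound 3 is small, a 1.3-fold lower number from compound 1 to compound 3 (0.10 log units; within the scatter), and probably not beyond the scatter in this assay. Compound 3 is estimated at 6500 nM, in the range 3000 nM to 14000 nM.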

Compound 3, half-maximal inhibitory concentration: 5600 nM
Beside the measured number, compound 3's estimate is 1.2-fold (0.06 log units) above it, within the range that was stated.
By their numbers in this assay, from the lowest: compounds 2, 3 and 1 (each within the scatter of the next).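

Within the data shown here, until now no two measured compounds differed in only one place, so this is the first reading of a single change. In this assay the exchange of 4-methylphenyl for 4-chlorophenyl gives a 1.5-fold lower number from compound 1 to compound 3 (0.17 log units; within the scatter) and so shows that, at this position, methyl and chloro cannot be told apart on potency. Nothing measured here offers a reason for this result.

Still open, from the compounds shown here alone, is whether a different kind of group at this position, such as an amine, a carboxylic acid or a nitrile, would move the number beyond the scatter. Going by these compounds, it is also open whether the same exchange of methyl for chloro would stay this small on a compound that differs elsewhere from compound 1.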